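The compounds below may be only part of what the source reports. "The series", "measured", "known", "first", "only" and "open" are said of these compounds alone.

Compound 1 `COc1cc(-c2ccnc3cc(-c4ccc5cc[nH]c5c4)nn23)cc(OC)c1OC`: 55 nM
Compound 2 `COc1cc(-c2ccnc3cc(-c4ccc(N(C)C)cc4)nn23)cc(OC)c1OC`: 702 nM
Compound 3 `COc1cc(-c2ccnc3cc(-c4ccc5c(ccn5C)c4)nn23)cc(OC)c1OC`: 48 nM

All three compounds share a common core and were tested in a functional assay on B16-F0 cells (Mus musculus) for inhibition, read by CCK-8 assay, with a stated time of 48 h; a higher number here means a weaker inhibitor, a lower number a stronger inhibitor. Compound 3 gives the lowest of the three numbers, but its nearest neighbour is compound 1, and the step of a 1.1-fold lower number from compound 1 to compound 3 (0.06 log units; within the scatter) is within the scatter, so the two cannot be told apart. Compound 2 stands far from both: a 15-fold lower number from compound 2 to compound 3 (1.17 log units; beyond the scatter).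

Compound 4 `COc1cc(-c2ccnc3cc(-c4ccc(C(F)(F)F)cc4)nn23)cc(OC)c1OC` is not yet measured. It differs from compound 3 in one place: 4-(trifluoromethyl)phenyl in place of 1-methyl-1H-indol-5-yl on an aromatic carbon. Within the data shown here, two measured steps bear on this. Going from compound 1 to compound 2 swapped a fused two-ring indolyl group for a single phenyl ring carrying a para group, and the result was a 13-fold higher number from compound 1 to compound 2 (1.11 log units; beyond the scatter). Going the other way, from compound 2 to compound 3, restored a fused indolyl group and gave a 15-fold lower number from compound 2 to compound 3 (1.17 log units; beyond the scatter). Both times, trading the two-ring group for a one-ring phenyl moved the number up by a large amount. Among the measured compounds shown here, compound 4 makes the same kind of trade, so a large rise in the number is expected, a 15-fold higher number from compound 3 to compound 4 (1.16 log units; beyond the scatter), although the para group in compound 4 is not the one seen in compound 2. Compound 4 is therefore estimated at 700 nM, with a likely range from 200 nM to 2500 nM.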

Compound 4, half-maximal inhibitory concentration: 1770 nM
The estimate for compound 4 lay 2.5-fold (0.40 log units) below the measured number; the range from low to high includes it.
By their numbers in this assay, from the lowest: compounds 3 and 1 (each within the scatter of the next); then compound 2; then compound 4.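

Compound 4 is a second single phenyl ring at this position, and it sits far above both indolyl compounds, with (a 37-fold higher number from compound 3 to compound 4 (1.57 log units; beyond the scatter)) and (a 32-fold higher number from compound 1 to compound 4 (1.51 log units; beyond the scatter)), so the large rise seen with compound 2 is not confined to the dimethylamino group. The group carried on the phenyl ring also counts in this assay, since trifluoromethyl in place of dimethylamino gives (a 2.5-fold higher number from compound 2 to compound 4 (0.40 log units; beyond the scatter)), yet that step is modest beside the large steps that separate both phenyl compounds from both indolyl compounds. No measurement shown here accounts for any of these steps.

Among these four compounds, every indolyl group gives a lower number than every substituted phenyl group, but it remains open whether a second ring is what matters, since a plain phenyl ring with no added group, or a phenyl ring bearing a primary amine or a carboxylic acid, could fall anywhere relative to them. As far as these compounds go, it is equally open how far the low numbers extend to other fused two-ring groups, such as an indazolyl or a benzimidazolyl group, at this same place on the shared core.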